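Urea to amide on the shared core: compound 3

The source may report more compounds than this note shows. Statements on the series, on what has been measured and on what is new or still open speak of the compounds shown alone.

Measured so far:
compound 1, `O=C(Nc1cccc(-n2cc(-c3ccncc3)c(-c3cc(O)cc(Cl)c3)n2)c1)Nc1ccc(Cl)c(C(F)(F)F)c1`, -26.5%
compound 2, `COc1cc(Cl)cc(-c2nn(-c3cccc(NC(=O)Nc4ccc(Cl)c(C(F)(F)F)c4)c3)cc2-c2ccncc2)c1`, -48.3%
not yet measured: compound 3, `COc1cc(Cl)cc(-c2nn(-c3cccc(NC(=O)c4cccc(C(F)(F)F)c4)c3)cc2-c2ccncc2)c1`

Going by the values given here, in a functional assay on U-251 cells (Homo sapiens) for inhibition, read by sulforhodamine B assay, with a stated time of 48 h, tested at 10 uM (on this read-out higher numbers stand for a weaker effect at the one concentration tested and lower numbers for a stronger effect), compound 2 gives -48.3%, the lowest of the two numbers; the nearest is compound 1 with -26.5%, and the single measured step, a number 21.8 percentage points lower from compound 1 to compound 2 (beyond the scatter), concerns only the methyl-for-hydrogen change on the oxygen. Compound 3 alters a different part of the molecule: 3-(trifluoromethyl)phenyl in place of (4-chloro-3-(trifluoromethyl)phenyl)amino on a carbonyl carbon. Among the compounds with values here, no measured step touches the carbonyl side, so nothing says how large a step this change brings or in which direction. With the urea of compound 2 and its chlorine gone, the estimate rests on compound 2 alone and is wide. Compound 3 is expected to give -15%, between -55% and 35%, an estimated step of a number 33.3 percentage points higher from compound 2 to compound 3 (beyond the scatter), most likely a weaker effect than compound 2 but not ruled out to stay near it.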

Compound 3, a percentage reported as activity, at one concentration (the size of the read-out at that concentration, not a potency): 49.2%
The estimate for compound 3 lay 64.2 percentage points below the measured number, and the stated range ends below it.
By their numbers in this assay, from the lowest: compound 2; then compound 1; then compound 3.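

In this assay, the carbonyl side is a place where one change moves the read-out far: a number 97.5 percentage points higher from compound 2 to compound 3 (beyond the scatter), a large step where the change on the oxygen was modest, and the number passes from negative in compound 2 to positive in compound 3. The amino link with its hydrogen-bond donor and the chlorine leave together in this step, so their shares in it cannot be separated. No measurement at hand accounts for the size of the step.

From the compounds shown here alone, it remains open whether the amino link or the chlorine carries the step, which (3-(trifluoromethyl)phenyl)amino or 4-chloro-3-(trifluoromethyl)phenyl on the carbonyl carbon would address. Also open, going by these compounds, is how a saturated amine such as morpholine would read at this carbon.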